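Exchanging the Outer Aromatic Ring in a Kinase Inhibitor Pair

The source may report more compounds than this note shows. Statements on the series, on what has been measured and on what is new or still open speak of the compounds shown alone.

Two compounds have been measured in an assay on isolated protein for inhibition of tyrosine-protein kinase receptor UFO (Homo sapiens), read by LC-MS; on this read-out higher numbers stand for weaker inhibition and lower numbers for stronger inhibition:

Compound 1 `CN(Cc1ccc2nccn2c1)c1nnc(-c2ccc(-c3ccccc3)cc2)o1` gives 3160 nM.
Compound 2 `CN(Cc1ccc2nccn2c1)c1nnc(-c2ccc(-c3ccccc3C#N)cc2)o1` gives 3980 nM.

Among the compounds with values here, compound 2 is joined to compound 1 by the single measured step, a 1.3-fold higher number from compound 1 to compound 2 (0.10 log units; within the scatter); the two numbers cannot be told apart on this assay, and nothing further separates them.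

Compound 3 `Cc1noc(C)c1-c1ccc(-c2nnc(N(C)Cc3ccc4nccn4c3)o2)cc1` is obtained from compound 2 by 3,5-dimethyl-1,2-oxazol-4-yl in place of 2-cyanophenyl on an aromatic carbon. Within the data shown here, the one step measured so far adds a nitrile to the outer ring and leaves the ring itself in place, so it speaks only indirectly to a change in which the whole outer ring is replaced. It shows that a small change at this end of the molecule left the number unchanged within the scatter, and with nothing else to go on the expected step of a 1.1-fold lower number from compound 2 to compound 3 (0.06 log units; within the scatter) is likewise no larger than the scatter, in no firm direction. Compound 3 is therefore estimated at 3500 nM, within 1000 nM to 12000 nM.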

Compound 3, half-maximal inhibitory concentration: 31600 nM
Compound 3: middle estimate off by 9.0-fold (0.96 log units), on the low side; measured number outside the range, above it.
By their numbers in this assay, from the lowest: compounds 1 and 2 (each within the scatter of the next); then compound 3.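

Replacing the whole outer ring does what adding a nitrile to it did not: 3,5-dimethyl-1,2-oxazol-4-yl in place of 2-cyanophenyl gives a 7.9-fold higher number from compound 2 to compound 3 (0.90 log units; beyond the scatter), and the same group in place of phenyl gives a 10-fold higher number from compound 1 to compound 3 (1.00 log units; beyond the scatter). Both steps mean weaker inhibition, so this position, on an aromatic carbon para to a large group, does respond to what is placed there, even though the nitrile step alone stayed within the scatter. The data at hand offer no explanation for this loss.

The entering group differs from phenyl in ring size, ring atoms and methyl groups all at once, so these three features cannot be told apart. A pyridine ring, or a 1,2-oxazol-4-yl ring without the two methyl groups, would be needed to begin separating them.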